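The compounds below may be only part of what the source reports. "The series", "measured", "known", "first", "only" and "open" are said of these compounds alone.

Compounds measured so far in a functional assay with Oryctolagus cuniculus as the target; on this read-out higher numbers stand for weaker inhibition and lower numbers for stronger inhibition:
- Compound 1 `COc1ccc(-c2nc(CN(C)C)sc2-c2ccc(OC)cc2)cc1`: 96 nM
- Compound 2 `CNC(=O)NCc1nc(-c2ccc(OC)cc2)c(-c2ccc(OC)cc2)s1`: 22 nM

Of these two, compound 2 has the lower number, 22 nM, and so shows the stronger inhibition in this assay. The next compound to consider is compound 3 `COc1ccc(-c2nc(C(=O)N=C(N)N)sc2-c2ccc(OC)cc2)cc1`, which differs from compound 2 as follows: a group of 6 heavy atoms (2 carbon, 3 nitrogen, 1 oxygen; no ring) in place of a group of 6 heavy atoms (3 carbon, 2 nitrogen, 1 oxygen; no ring), on an aromatic carbon. The new group sits on an aromatic carbon of the five-membered aromatic ring.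

For the measured compounds named here, only one measured step bears on this change: a 4.4-fold lower number from compound 1 to compound 2 (0.64 log units; beyond the scatter). That step is modest but beyond the scatter. It replaced only the group on the chain carbon, whereas here the whole side group changes, so it is a loose guide. The data do not settle the direction, but a modest rise is expected. The expected step is a 2.7-fold higher number from compound 2 to compound 3 (0.44 log units; beyond the scatter). For compound 3 the estimated value is 60 nM, with an expected range of 15 nM to 240 nM.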

Compound 3, half-maximal inhibitory concentration: > 100 nM
Compound 3 was reported as a limit; the forecaster's own chance of this, stated with the estimate: 5%; at least 1.6-fold (0.22 log units) between middle value and limit.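

In this assay, replacing the ((methylcarbamoyl)amino)methyl group on the aromatic carbon of the five-membered aromatic ring gives an at least 4.5-fold higher number from compound 2 to compound 3 (0.65 log units; beyond the scatter). The two groups have the same counts of heavy atoms, hydrogen-bond donors and hydrogen-bond acceptors, so these counts alone do not decide the result at this position, and the comparison with the dimethylamino side chain gives only an at least 1.0-fold higher number from compound 1 to compound 3 (0.01 log units; that floor lies within the scatter), which sets no order between those two compounds. Compound 3 has no exact number, only a limit: the limit of > 100 nM in this assay, at which 1 of the 3 values shown sits.

The compounds shown leave open how far the true value of compound 3 lies from that limit. They also leave open how a carboxylic acid on this aromatic carbon, or a longer chain ending in the (methylcarbamoyl)amino group, would read out.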